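A few compounds are considered here, and "the series" means these few. Any claim that something is new, unique, unknown or untested is made for them only; others in the source may bear on it.

Measured compounds:
Compound 1 `O=C(NNC(=O)c1ccccc1F)c1ccc(NS(=O)(=O)c2cnc(O)nc2O)cc1`. In a functional assay on MDA-MB-231 cells (Homo sapiens) for antiproliferative activity, read by MTT assay, with a stated time of 24 h (a lower number here means a stronger inhibitor, a higher number a weaker inhibitor), compound 1 gives > 20000 nM, which is a limit of the assay and not a number.
Compound 2 `O=C(NNC(=O)c1ccc(NS(=O)(=O)c2cnc(O)nc2O)cc1)c1ccc(F)cc1`. In this assay compound 2 gives > 20000 nM, again a limit.
Compound 3 `O=C(NNC(=O)c1ccccc1F)c1cccc(NS(=O)(=O)c2cnc(O)nc2O)c1`. In this assay compound 3 gives > 20000 nM, also a limit.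

All three values sit at the limit of > 20000 nM in this assay, at which 3 of the 3 values shown sit. Compound 2 differs from compound 1 by 4-fluorophenyl in place of 2-fluorophenyl on a carbonyl carbon; the step that the two limits leave unreadable from compound 1 to compound 2 is left unreadable by the two limits. The difference between the cores of compound 1 and compound 3 is not broken down here. Compound 4 `O=C(NNC(=O)c1cccc(NS(=O)(=O)c2cnc(O)nc2O)c1)c1ccc(F)cc1` is not yet measured in this assay; it differs from compound 3 by 4-fluorophenyl in place of 2-fluorophenyl on a carbonyl carbon, the same change as that from compound 1 to compound 2, at the same place. With every value shown at the limit and the earlier step unreadable, for compound 4 the estimated step is a step that the limit leaves unreadable from compound 3 to compound 4. Compound 4 is expected at 30000 nM, between 15000 nM and 100000 nM, most likely reported as a limit.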

Compound 4, half-maximal inhibitory concentration: > 20000 nM
Compound 4 ended at the assay's limit; the forecaster's own chance of this, stated with the estimate: 85%; the middle value does not contradict the limit.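

No step can be read from compound 3 to compound 4 or from compound 1 to compound 2, as each compound's result is a limit and not a number: the limit of > 20000 nM in this assay, at which 4 of the 4 values shown sit.

The compounds shown leave open whether 4-fluorophenyl in place of 2-fluorophenyl changes activity at all in this assay.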